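The source may hold more compounds than are shown below. What is called first, only, known or untested is meant among the compounds shown, and "the series" means these compounds.

Compound 1 `CCc1ccccc1NC(=O)N[C@H](C)c1ccccc1`: 101%
Compound 2 `CCc1ccccc1NC(=O)N[C@@H](C)c1ccccc1`: 100%
Compound 3 `CCCCCCc1ccc(NC(=O)N[C@@H](C)c2ccccc2)cc1`: 99%

Of the compounds shown here, three have been measured in an ADME assay on the whole organism with Oryza sativa as the target, tested at 0.1 uM; a higher number here means a weaker effect of the compound at the concentration tested, a lower number a stronger effect. Compound 1 gives 101%, compound 2 gives 100% and compound 3 gives 99%; compound 1 stands highest of the three numbers, though both other values lie within the scatter of it. Among the compounds with values here, the single measured step between compounds differing in one place is a number 1 percentage points lower from compound 1 to compound 2 (within the scatter), which rests on (the fact that compounds 1 and 2 differ only in the configuration as drawn). Compound 4, `CC(=O)c1ccccc1NC(=O)N[C@H](C)c1ccccc1`, carries acetyl in place of ethyl on an aromatic carbon. Within the data shown here, no measured step touches an exchange of this kind, and the configuration step from compound 1 to compound 2 says nothing about a change at an aromatic carbon. The expected step is therefore a number 2 percentage points lower from compound 1 to compound 4 (within the scatter), none beyond the scatter. Compound 4 is estimated at 99%, between 85% and 106%.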

Compound 4, a percentage reported as activity, at one concentration (the size of the read-out at that concentration, not a potency): 96%
Compound 4: middle estimate off by 3 percentage points, on the high side; low and high end bracket the measured number.
By their numbers in this assay, from the lowest: compounds 4, 3, 2 and 1 (each within the scatter of the next).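

In this assay, placing acetyl in place of ethyl on this aromatic carbon, ortho to a large group, adds an oxygen and a hydrogen-bond acceptor to the core of compound 1, and the outcome is a number 5 percentage points lower from compound 1 to compound 4 (within the scatter). This position therefore takes that exchange with no change that stands clear of the scatter. No available evidence bears on this exchange.

On these data alone, whether an amine, a carboxylic acid or a longer chain at this aromatic carbon would move the number beyond the scatter remains open. Also open, as far as these compounds go, is whether acetyl would behave alike on the opposite configuration, that of compound 2.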